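Working notes: a single stereocentre change from compound 2

The source may hold more compounds than are shown below. What is called first, only, known or untested is meant among the compounds shown, and "the series" means these compounds.

Measured in a functional assay on HCT-8 cells (Homo sapiens) for cytotoxicity, read by MTT assay, with a stated time of 24 h; on this read-out higher numbers stand for weaker inhibition and lower numbers for stronger inhibition (both values are limits, not numbers):
- compound 1 `CC(C)C1=C[C@]2(O)CC[C@H]3[C@]4(C)CCC[C@]3(C(=O)OC4)C2=CC1=O` gives > 10000 nM
- compound 2 `CC(C)c1cc2c(cc1O)[C@]13CCC[C@](C)(CO[C@H]1O)[C@@H]3CC2` gives > 10000 nM

Compound 2 stands at a limit of this assay (> 10000 nM), not at a number. Going by the values given here, the whole series so far comes down to one entry (the limit of > 10000 nM in this assay, at which 2 of the 2 values shown sit), and no step between measured compounds gives a size. Compound 3 `CC(C)c1cc2c(cc1O)[C@]13CCC[C@](C)(CO[C@@H]1O)[C@@H]3CC2` is still unmeasured. Its relation to compound 2 is this: (the two compounds have the same atoms and bonds and differ only in configuration as drawn: 1 of 4 stereo elements differ; a stereocentre at a saturated ring carbon is drawn R in compound 2 and S in compound 3). The atoms and bonds stay as they are, and only the drawn configuration at that saturated ring carbon changes. No step beyond the scatter is expected in this assay, in either direction. The expected step (a step that the limit leaves unreadable from compound 2 to compound 3) stays within the scatter. Compound 3 is estimated at 15000 nM (expected range 6000 nM to 40000 nM), most likely reported again as a limit.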

Compound 3, half-maximal inhibitory concentration: > 10000 nM
Compound 3: a limit, no number; the forecaster's own chance of this, stated with the estimate: 85%; the middle value is on the limit's open side.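

Going by these compounds alone, compound 2 and compound 3 are both reported only as limits, and no step between them can be read. The compounds shown leave open whether the drawn configuration at the saturated ring carbon has any effect, and what actual number any of them would give in this assay.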